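Benzyl in Place of Nitro on a Citrate-Like Inhibitor

This account rests on a few compounds, and the source may have more. Where it says the series, first, only, none or still open, it means among the compounds named here.

Compound 1, `O=C(O)CC(O)(CSCCCc1ccc(Cl)cc1Cl)C(=O)O`: 390000 nM
Compound 2, `COc1ccc(CCCCCCSCC(O)(CC(=O)O)C(=O)O)cc1`: 280000 nM
Compound 3, `O=C(O)CC(O)(CSCCCCCCc1ccccc1[N+](=O)[O-])C(=O)O`: 75000 nM

Three compounds share a citrate-like core carrying a sulfur-linked chain that ends in a substituted aromatic ring, and all were tested in an assay on isolated protein for inhibition of ATP-citrate synthase (Rattus norvegicus); a higher number here means a weaker inhibitor, a lower number a stronger inhibitor. Compound 3 gives the lowest number of the three; compound 2 stands well above it, and compound 1 stands furthest away, both gaps beyond the scatter of repeated measurements.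

The next compound, compound 4, `O=C(O)CC(O)(CSCCCCCCc1ccccc1Cc1ccccc1)C(=O)O`, is not yet measured. It differs from compound 3 in one place: benzyl in place of nitro on an aromatic carbon. Within the data shown here, none of the measured pairs differ in a single place, so no directly comparable step exists, and the expectation rests only on the spread seen among compounds 1, 2 and 3.

Among the measured compounds shown here, compound 4 is expected to show a modest fall in the number, a step of a 1.7-fold lower number from compound 3 to compound 4 (0.22 log units; within the scatter), with wide uncertainty because compound 3 itself is only at 75000 nM and the set gives no prior example of this kind of exchange. The estimate for compound 4 is 45000 nM, in a range from 12000 nM to 170000 nM.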

Compound 4, inhibition constant: 94000 nM
Estimate against measurement, compound 4: 2.1-fold (0.32 log units) below; the range from low to high includes it.
By their numbers in this assay, from the lowest: compounds 3 and 4 (each within the scatter of the next); then compounds 2 and 1 (each within the scatter of the next).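

Among these compounds, exchanging nitro for benzyl on this aromatic carbon, ortho to a large group, gives in this assay a 1.3-fold higher number from compound 3 to compound 4 (0.10 log units; within the scatter), the first comparison here between compounds that differ in only one place. At this position, then, a larger group that brings its own aromatic ring and no hydrogen-bond acceptors can replace nitro, which has hydrogen-bond acceptors, with no change beyond the usual scatter of the measurement. Nothing in the available data explains why these two groups read alike.

On these data alone, whether an amine or a carboxylic acid on the same aromatic carbon would shift the number beyond the scatter remains open. Among the compounds shown here, also open is whether the exchange of nitro for benzyl would read the same on a longer chain than the one shared by compound 3 and compound 4.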